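A few compounds are considered here, and "the series" means these few. Any claim that something is new, unique, unknown or untested is made for them only; others in the source may bear on it.

Within the data shown here, in a functional assay on KYSE-70 cells for antiproliferative activity against KYSE-70 cell line (Homo sapiens), read by MTT assay, with a stated time of 72 h (a higher number here means a weaker inhibitor, a lower number a stronger inhibitor), compound 1 `O=C(Nc1cccc(F)c1)c1cc(=O)[nH]c2cc(Br)ccc12` gives 8900 nM, the only exact number so far. Compound 2 `COc1cccc(NC(=O)c2cc(=O)[nH]c3cc(Br)ccc23)c1` reads > 20000 nM, which is a limit of the assay. Compound 3 `O=C(Nc1cccc(Cl)c1)c1cc(=O)[nH]c2cc(Br)ccc12` reads > 20000 nM, also a limit. Replacing the fluoro of compound 1 thus gave an at least 2.2-fold higher number from compound 1 to compound 2 (0.35 log units; beyond the scatter) with methoxy and an at least 2.2-fold higher number from compound 1 to compound 3 (0.35 log units; beyond the scatter) with chloro. Compound 4 `O=C(Nc1cccc(F)c1)c1cc(=O)[nH]c2cc(-c3ccc(F)cc3)ccc12` keeps that fluoro and changes another site: 4-fluorophenyl in place of bromo on an aromatic carbon, 4-fluorophenyl in place of bromo. Among the measured compounds shown here, no measured step tests this swap directly, so neither direction can be favoured, and no step beyond the scatter is expected. The expected result is a 1.1-fold lower number from compound 1 to compound 4 (0.05 log units; within the scatter). For compound 4 the estimate is 8000 nM, with an expected range of 2000 nM to 20000 nM.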

Compound 4, half-maximal inhibitory concentration: 3300 nM
Beside the measured number, compound 4's estimate is 2.4-fold (0.38 log units) above it, and the stated range covers the measured number.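

Among these compounds, the earlier steps all changed the fluoro site, and they only raised the number; this is the first change at the bromo site and the first to lower it. In this assay, 4-fluorophenyl in place of bromo gives a 2.7-fold lower number from compound 1 to compound 4 (0.43 log units; beyond the scatter). This site therefore holds a whole added aromatic ring, and activity improves beyond the scatter.

As far as these compounds go, whether a plain phenyl or an amine at this site would do the same remains open. Whether this swap would also lower the numbers of compound 2 and compound 3 is open too, as both compounds sit at a limit rather than a number: the limit of > 20000 nM in this assay, at which 2 of the 4 values shown sit.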